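A Trifluoromethyl Swap Among Three Limits

The source may hold more compounds than are shown below. What is called first, only, known or untested is meant among the compounds shown, and "the series" means these compounds.

Within the data shown here, in an ADME assay on HepG2 cells (Homo sapiens) for cytotoxicity, read by MTT assay, with a stated time of 72 h (a higher number here means that more compound is tolerated, a lower number that less compound is tolerated), no measured compound yet has a number. Compound 1 `O=[N+]([O-])c1c(CS(=O)(=O)c2ccccc2)nc2c(-c3ccccc3)cc(Cl)cn12` gives > 15600 nM here, which is a limit. Compound 2 `O=Cc1ccc(-c2cc(Cl)cn3c([N+](=O)[O-])c(CS(=O)(=O)c4ccccc4)nc23)cc1` gives > 31200 nM here, also a limit. Compound 3 `O=[N+]([O-])c1c(CS(=O)(=O)c2ccccc2)nc2c(-c3ccc(F)cc3F)cc(Cl)cn12` gives > 7800 nM here, again a limit, so it stands beside the other two with no readable value.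

Compound 4 `O=[N+]([O-])c1c(CS(=O)(=O)c2ccccc2)nc2c(-c3ccc(C(F)(F)F)cc3)cc(Cl)cn12` carries 4-(trifluoromethyl)phenyl in place of the 2,4-difluorophenyl of compound 3 on an aromatic carbon, and the count of that change is 4-(trifluoromethyl)phenyl in place of 2,4-difluorophenyl on an aromatic carbon in full.

Two measured changes at this same place bear on it. One is a step that the two limits leave unreadable from compound 1 to compound 3 and the other is a step that the two limits leave unreadable from compound 2 to compound 3 so neither offers a size or a direction to carry over. No step beyond the scatter is therefore expected in this assay for this swap. The expected change is a step that the limit leaves unreadable from compound 3 to compound 4 and it remains only an estimate. Compound 4 is expected at 10000 nM with an estimated range of 4000 nM to 30000 nM and may well return only a limit.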

Compound 4, half-maximal cytotoxic concentration: > 3900 nM
Compound 4 gave a limit, no number (the forecaster's own chance of this, stated with the estimate: 75%); the middle value does not contradict the limit.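

In this assay compound 4 gives > 3900 nM, which is a limit. Its steps from compound 1, compound 2 and compound 3 cannot be read, as all four values are limits. The compounds shown leave open what half-maximal cytotoxic concentration any of them has, and whether these swaps change it.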